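The source may hold more compounds than are shown below. What is called first, only, known or untested is meant among the compounds shown, and "the series" means these compounds.

Compound 1 `Nc1ccc2nc(N)sc2c1`: > 10 mg/kg, a limit.
Compound 2 `CCCCCCCc1ccc2nc(N)sc2c1`: > 10 mg/kg, a limit.
Compound 3 `C#CCn1c(=N)sc2cc(OC(F)(F)F)ccc21`: 4 mg/kg.

All three were tested in a functional assay on the whole organism with Rattus norvegicus as the target; on this read-out higher numbers stand for an effect only at larger amounts of compound and lower numbers for an effect already at smaller amounts. Compound 3 is the only one of them to give a number rather than a limit. The other two reach only a limit, (the limit of > 10 mg/kg in this assay, at which 2 of the 3 values shown sit).

Compound 4 `N=c1sc2cc(OC(F)(F)F)ccc2n1CCS(N)(=O)=O` differs from compound 3 in one place: sulfamoylmethyl in place of ethynyl on a saturated chain carbon bound to an aromatic nitrogen. In words, propargyl gives way to 2-sulfamoylethyl. Within the data shown here, no measured pair shows this kind of change, so the expectation rests on compound 3 alone, at 4 mg/kg. The expected change is small and stays within the usual scatter: a 1.3-fold higher number from compound 3 to compound 4 (0.10 log units; within the scatter). For compound 4 the estimate is 5 mg/kg, with an expected range of 1.5 mg/kg to 15 mg/kg.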

Compound 4, dose for half-maximal effect: 6 mg/kg
Estimate against measurement, compound 4: 1.2-fold (0.08 log units) below; measured number inside the range.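

In this assay, among these compounds, sulfamoylmethyl in place of ethynyl on a saturated chain carbon bound to an aromatic nitrogen gives a 1.5-fold higher number from compound 3 to compound 4 (0.18 log units; within the scatter), the first step that can be read at this place. This place therefore takes the larger group, with its hydrogen-bond donor and acceptors, without a change beyond the scatter. Compound 4 gives a number rather than a limit, as compound 3 does: the limit of > 10 mg/kg in this assay, at which 2 of the 4 values shown sit.

With a single step, the compounds shown leave open how an amine, a carboxylic acid or a longer chain would read at this place.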